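The compounds below may be only part of what the source reports. "The series", "measured", "known", "first", "only" and "open" are said of these compounds alone.

Measured so far:
compound 1 `Cc1nc(S(C)(=O)=O)ccc1Oc1ncnc(OC2CCN(C(=O)OC(C)(C)C(F)(F)F)CC2)c1F` — 47.2 nM in a functional assay on isolated protein for inhibition of Glucose-dependent insulinotropic receptor (Rattus norvegicus), read by HTRF and cAMP accumulation; a higher number here means that more compound is needed for the effect, a lower number that less compound is needed
compound 2 `Cc1nc(S(C)(=O)=O)ccc1Oc1ncnc(OC2CCN(C(=O)O[C@H](C)C(F)(F)F)CC2)c1F` — 110 nM
compound 3 `CCC1(OC(=O)N2CCC(Oc3ncnc(Oc4ccc(S(C)(=O)=O)nc4C)c3F)CC2)CC1` — 333 nM

Compound 3 gives the highest number of the three: a 7.1-fold higher number from compound 1 to compound 3 (0.85 log units; beyond the scatter) and a 3.0-fold higher number from compound 2 to compound 3 (0.48 log units; beyond the scatter). Compound 4 `Cc1nc(S(C)(=O)=O)ccc1Oc1ncnc(OC2CCN(C(=S)OC3(C)CC3)CC2)c1F` differs from compound 3 by a group of 7 heavy atoms (5 carbon, 1 oxygen, 1 sulfur; one three-membered non-aromatic ring of carbon only) in place of a group of 8 heavy atoms (6 carbon, 2 oxygen; one three-membered non-aromatic ring of carbon only), on an amine nitrogen in a ring. Going by the values given here, no measured step touches the carbonyl itself; the three steps measured change only the group on an oxygen next to a carbonyl group, and all were modest, with a 2.3-fold higher number from compound 1 to compound 2 (0.37 log units; beyond the scatter) the smallest. Compound 4 is expected to move only slightly, in either direction or not beyond the scatter, a 1.1-fold lower number from compound 3 to compound 4 (0.05 log units; within the scatter). Compound 4 is therefore estimated at 300 nM in this assay, within a range from 90 nM to 1000 nM.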

Compound 4, half-maximal effective concentration: 48.8 nM
Compound 4: middle estimate off by 6.1-fold (0.79 log units), on the high side, and the stated range ends above it.
By their numbers in this assay, from the lowest: compounds 1 and 4 (each within the scatter of the next); then compound 2; then compound 3.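

Changing the carbonyl itself matters in this assay: a 6.8-fold lower number from compound 3 to compound 4 (0.83 log units; beyond the scatter), although the group on oxygen differs as well, so the effects of sulfur and of the ring substituent cannot be separated. The same group gives a 2.3-fold lower number from compound 2 to compound 4 (0.35 log units; beyond the scatter) and a 1.0-fold higher number from compound 1 to compound 4 (0.01 log units; within the scatter), so without fluorine it reaches the level of the 1-methyl-1-(trifluoromethyl)ethyl compound. Nothing available explains this shift.

The compounds shown leave open whether a plain carbonyl with 1-methylcyclopropyl on oxygen would match compound 4. They also leave open whether a thiocarbonyl with 1-methyl-1-(trifluoromethyl)ethyl on oxygen would go lower still.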